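Swapping Cyclohexyl for Trimethoxyphenyl in a Cytotoxicity Series

This account rests on a few compounds, and the source may have more. Where it says the series, first, only, none or still open, it means among the compounds named here.

Measured compounds in a functional assay on MDA-MB-231 cells (Homo sapiens) for cytotoxicity, read by MTT assay, with a stated time of 72 h; on this read-out lower numbers stand for stronger inhibition and higher numbers for weaker inhibition:
compound 1 `COc1ccc(Cn2nc(-c3ccccc3)c3cc(C(=N)Nc4cccc(C(F)(F)F)c4)nc(NC4CCCCC4)c32)cc1` gives > 50000 nM
compound 2 `COc1cc(Nc2nc(C(=N)Nc3ccccc3)cc3c(-c4ccccc4)n[nH]c23)cc(OC)c1OC` gives 4500 nM
compound 3 `N=C(Nc1ccccc1)c1cc2c(-c3ccccc3)n[nH]c2c(NC2CCCCC2)n1` gives 1710 nM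

Compound 1 gives only a limit of the assay and not a number. Compound 3 and compound 2 differ in one place: 3,4,5-trimethoxyphenyl in place of cyclohexyl on a nitrogen on an aromatic ring. That change gave a 2.6-fold higher number from compound 3 to compound 2 (0.42 log units; beyond the scatter). The unmeasured compound 4 `COc1ccc(Cn2nc(-c3ccccc3)c3cc(C(=N)Nc4cccc(C(F)(F)F)c4)nc(Nc4cc(OC)c(OC)c(OC)c4)c32)cc1` arises from compound 1 by the same change, (3,4,5-trimethoxyphenyl in place of cyclohexyl on a nitrogen on an aromatic ring), at the same place in both pairs. How the core of compound 1 differs from that of compound 3 is not broken down here. Because compound 1 already sits at the limit of > 50000 nM in this assay, at which 1 of the 3 values shown sits, compound 4 is expected to stay at or beyond that limit, with an expected step that the limit leaves unreadable from compound 1 to compound 4 in this assay. The estimate for compound 4 is 90000 nM, expected between 25000 nM and 400000 nM, and most likely reported only as a limit.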

Compound 4, half-maximal inhibitory concentration: > 50000 nM
Compound 4: no number, only a limit; the forecaster's own chance of this, stated with the estimate: 85%; the middle value is on the limit's open side.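

Compound 1 and compound 4 both give only a limit of the assay, so no step between them can be read: the limit of > 50000 nM in this assay, at which 2 of the 4 values shown sit.

Left open is whether 3,4,5-trimethoxyphenyl in place of cyclohexyl changes anything on the core of compound 1, as it did between compound 3 and compound 2.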